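A few compounds are considered here, and "the series" means these few. Any claim that something is new, unique, unknown or untested is made for them only; others in the source may bear on it.

Compound 1 `O=C1NC(=O)/C(=C\c2ccc(OCC(=O)N3N=C(c4ccccc4)CC3c3ccc(C(F)(F)F)cc3)cc2)S1`: 1000 nM
Compound 2 `Cc1ccc(C2CC(c3ccccc3)=NN2C(=O)COc2ccc(/C=C3/SC(=O)NC3=O)cc2)cc1`: 1200 nM
Compound 3 `O=C1NC(=O)/C(=C\c2ccc(OCC(=O)N3N=C(c4ccc(F)cc4)CC3c3ccc(C(F)(F)F)cc3)cc2)S1`: 1300 nM

All three were measured in an assay on cells for inhibition of histone deacetylase 4 (Homo sapiens), read by fluorescence, with a stated time of 30 min; on this read-out lower numbers stand for stronger inhibition and higher numbers for weaker inhibition. Compound 3 has the highest of the three numbers, but its gaps to compound 2 and to compound 1 are both within the scatter, so the three stand level. Compound 4 `Cc1ccc(C2CC(c3ccc(F)cc3)=NN2C(=O)COc2ccc(/C=C3/SC(=O)NC3=O)cc2)cc1` differs from compound 3 in one place: methyl in place of trifluoromethyl on an aromatic carbon. The same exchange has been seen once before, as a 1.2-fold higher number from compound 1 to compound 2 (0.08 log units; within the scatter), a step too small to count as a change. The other measured step, a 1.3-fold higher number from compound 1 to compound 3 (0.11 log units; within the scatter), was equally small. A step of similar size is therefore expected here, a 1.2-fold higher number from compound 3 to compound 4 (0.06 log units; within the scatter), with nothing beyond the scatter. Compound 4 is estimated at 1500 nM, with a range from 750 nM to 3000 nM.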

Compound 4, half-maximal inhibitory concentration: 1800 nM
The estimate for compound 4 lay 1.2-fold (0.08 log units) below the measured number; the measured number falls inside the stated range.
By their numbers in this assay, from the lowest: compounds 1, 2, 3 and 4 (each within the scatter of the next).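

With a fluoro group already in place, methyl in place of trifluoromethyl gives a 1.4-fold higher number from compound 3 to compound 4 (0.14 log units; within the scatter), and with methyl already in place, fluoro in place of hydrogen gives a 1.5-fold higher number from compound 2 to compound 4 (0.18 log units; within the scatter), so neither change moves the number beyond the scatter in this second setting. The methyl exchange now repeats with much the same size: the same change on two cores in this assay, a 1.2-fold higher number (0.08 log units; within the scatter) from compound 1 to compound 2 and a 1.4-fold higher number (0.14 log units; within the scatter) from compound 3 to compound 4, 1.2-fold (0.06 log units) apart, within the scatter of two such steps. The fluoro exchange does the same: the same change on two cores in this assay, a 1.3-fold higher number (0.11 log units; within the scatter) from compound 1 to compound 3 and a 1.5-fold higher number (0.18 log units; within the scatter) from compound 2 to compound 4, 1.2-fold (0.06 log units) apart, within the scatter of two such steps.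

Only trifluoromethyl and methyl appear on this aromatic carbon. From the compounds shown here alone, whether an amine or a carboxylic acid there would shift the number remains open.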